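Removing one methoxy from a trimethoxyphenyl pyrazole chalcone

This account rests on a few compounds, and the source may have more. Where it says the series, first, only, none or still open, it means among the compounds named here.

Measured compounds:
compound 1, `COc1ccc(-c2cc(/C=C/C(=O)c3ccc(N)cc3)[nH]n2)cc1`: 105%
compound 2, `COc1cc(-c2cc(/C=C/C(=O)c3ccc(N)cc3)[nH]n2)cc(OC)c1OC`: 97%
compound 3, `COc1cc(-c2cc(/C=C/C(=O)c3ccc(F)c(F)c3)[nH]n2)cc(OC)c1OC`: 102%

In a functional assay on HCT-116 cells (Homo sapiens) for cytotoxicity, read by sulforhodamine B assay, with a stated time of 48 h, tested at 0.1 uM (on this read-out lower numbers stand for a stronger effect and higher numbers for a weaker effect at the one concentration tested), compound 2 gives 97%, and compound 3 and compound 1 both lie within the scatter of it. Going by the values given here, the one measured single step, a number 5 percentage points higher from compound 2 to compound 3 (within the scatter), changes the group on the carbonyl carbon, not the methoxy-bearing ring, so it does not bear directly on the change considered here. Compound 4, `COc1ccc(-c2cc(/C=C/C(=O)c3ccc(N)cc3)[nH]n2)cc1OC`, differs from compound 2 by hydrogen in place of methoxy on an aromatic carbon. Compound 1 and compound 2, which differ in two methoxy groups, give numbers within the scatter of each other, and nothing measured points to a step beyond the scatter. Compound 4 is therefore expected to give 100% in this assay, between 88% and 112%, a step of a number 3 percentage points higher from compound 2 to compound 4 (within the scatter).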

Compound 4, a percentage reported as activity, at one concentration (the size of the read-out at that concentration, not a potency): 101%
Compound 4: the middle estimate sits 1 percentage points below what was measured; the range from low to high includes it.
By their numbers in this assay, from the lowest: compounds 2, 4, 3 and 1 (each within the scatter of the next).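

In this assay hydrogen in place of methoxy on an aromatic carbon gives a number 4 percentage points higher from compound 2 to compound 4 (within the scatter) while methoxy in place of hydrogen gives a number 4 percentage points lower from compound 1 to compound 4 (within the scatter) and so this position is now read directly, from both sides. At this one concentration, neither single change to a methoxy group moves the number beyond the scatter. Nothing on hand offers an explanation for this result. From the compounds shown here alone, whether a hydroxy group or a chlorine atom at this position would behave the same remains open. So does whether these steps would stay within the scatter at a higher concentration.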